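A few compounds are considered here, and "the series" means these few. Any claim that something is new, unique, unknown or untested is made for them only; others in the source may bear on it.

Values in a functional assay on MCF7 cells (Homo sapiens) for antiproliferative activity, read by MTT assay, with a stated time of 48 h (on this read-out lower numbers stand for stronger inhibition and higher numbers for weaker inhibition), as follows
- compound 1 `COC(=O)/C(=C/c1ccccc1)CN1C(=O)[C@@H](OC)[C@H]1c1ccc(Cl)cc1` gives 15300 nM
- compound 2 `CCOC(=O)/C(=C/c1ccccc1)CN1C(=O)[C@@H](OC)[C@H]1c1ccc(Cl)cc1` gives 12700 nM
- compound 3 `COC(=O)/C(=C/c1ccccc1)CN1C(=O)[C@@H](OC)[C@H]1c1cccc(Cl)c1` gives 25100 nM

All three numbers lie close together. Among the measured compounds shown here, compound 2, at 12700 nM, sits within the scatter of compound 1 and of compound 3, so the series so far shows no clear separation in this assay.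

The next compound is compound 4 `CCOC(=O)/C(=C/c1ccccc1)CN1C(=O)[C@@H](OC)[C@H]1c1cccc([N+](=O)[O-])c1`, which keeps the rest of compound 2 and changes one group: 3-nitrophenyl in place of 4-chlorophenyl on a saturated ring carbon. Two measured steps are available. The first, a 1.2-fold lower number from compound 1 to compound 2 (0.08 log units; within the scatter), concerns a different place in the molecule and says little about this change. For the measured compounds named here, the second, a 1.6-fold higher number from compound 1 to compound 3 (0.21 log units; within the scatter), is the only measured change to this aryl group and is the closer guide, though it stays with chlorine. Going by the values given here, no compound with a nitro group has been measured, so the effect of that group is unknown. Both measured steps are small, so no step beyond the scatter is expected, with at most a slight drift towards a higher number, as in the step to compound 3.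

An estimated 1.5-fold higher number from compound 2 to compound 4 (0.17 log units; within the scatter) is therefore the working expectation. For compound 4 the expected value is 19000 nM, with an estimated range of 6000 nM to 50000 nM.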

Compound 4, half-maximal inhibitory concentration: 19900 nM
Beside the measured number, compound 4's estimate is 1.0-fold (0.02 log units) below it, within the range that was stated.
By their numbers in this assay, from the lowest: compounds 2, 1, 4 and 3 (each within the scatter of the next).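

Within this assay, 3-nitrophenyl in place of 4-chlorophenyl on the saturated ring carbon gives a 1.6-fold higher number from compound 2 to compound 4 (0.20 log units; within the scatter), the first step in the series that brings a nitro group to this position. The earlier compounds shown here carried only a chlorine on this aryl group, so they could not show that a nitro-bearing aryl group stays within the scatter of a chlorine-bearing one at this place on the four-membered ring. The change alters both the kind of substituent and its place on the phenyl ring, so this single step cannot assign any share of the small difference to either, and no available data bear on why the step is this small.

All four compounds remain within the scatter of their neighbours in the ordered values, so no feature of this aryl group has yet been tied to a clear separation in this assay. Open, from the compounds shown here alone, is whether a group of another kind on this phenyl ring, such as an amine or a carboxylic acid, would leave the numbers in the same band or move them beyond the scatter.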